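The compounds below may be only part of what the source reports. "The series", "measured", "known", "first", "only" and "open" are said of these compounds alone.

Measured compounds:
- Compound 1, `CNC(=O)c1nc(-c2cccs2)[nH]c(=O)c1O`: in an assay on isolated protein for inhibition of deoxyribonuclease-1 (Homo sapiens) (a lower number here means a stronger inhibitor, a higher number a weaker inhibitor), compound 1 gives 67600 nM.
- Compound 2, `O=C(c1nc(-c2cccs2)[nH]c(=O)c1O)N1CCCC1`: in this assay compound 2 gives "not determined" (no result reported).
- Compound 3, `CC(C)CCNC(=O)c1nc(-c2cccs2)[nH]c(=O)c1O`: in this assay compound 3 gives "not determined" (no result reported).

Compound 3 therefore stands without a number of its own, and compound 2 shares that gap; the only figure in hand is the weak one for compound 1, whose shared core carries a small chain on the amide nitrogen. Compound 4, `O=C(Nc1cccnc1)c1nc(-c2cccs2)[nH]c(=O)c1O`, differs from compound 3 in one place: pyridin-3-yl in place of isopentyl on an amide-type nitrogen. Among the compounds with values here, no measured pair shows what such a swap does, so no direction can be read from the data, and a step of modest size in either sense would not be surprising. Compound 4 is expected to remain a weak inhibitor, with an estimated value of 40000 nM, ranging from 6000 nM to 250000 nM.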

Compound 4, half-maximal inhibitory concentration: > 100000 nM
Compound 4 ended at the assay's limit; the forecaster's own chance of this, stated with the estimate: 30%; middle value at least 2.5-fold (0.39 log units) away from the limit.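

In this assay compound 4 gives > 100000 nM, which is a limit of the assay and not a number. Placing an aromatic ring on the amide-type nitrogen gives an at least 1.4-fold higher number from compound 1 to compound 4 (0.17 log units; that floor lies within the scatter), so pyridin-3-yl brings no gain in strength here, though a real loss is not shown either. The change from isopentyl to pyridin-3-yl cannot be read, as compound 3 has no number.

Open, as far as these compounds go, is what a chain ending in an amine or a carboxylic acid would give on this nitrogen. Also open, from the compounds shown here alone, is whether any group there can give a lower number than compound 1.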